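Cytotoxicity notes on a chalcone series: compound 3 to compound 4

The source may report more compounds than this note shows. Statements on the series, on what has been measured and on what is new or still open speak of the compounds shown alone.

Three compounds have been run in an ADME assay on Vero cells (Chlorocebus sabaeus) for cytotoxicity, with a stated time of 72 h; on this read-out lower numbers stand for higher toxicity in this test and higher numbers for lower toxicity in this test. Compound 1 `O=C(/C=C/c1ccc(Cl)cc1)c1ccc(NCc2ccco2)cc1` gives 404 ug/mL, compound 2 `O=C(/C=C/c1ccc(Cl)cc1)c1ccc(N2CCCCC2)cc1` gives 235 ug/mL, and compound 3 `CCCCCCCNc1ccc(C(=O)C2CC2c2ccc(Cl)cc2)cc1` gives 398 ug/mL. Among the measured compounds shown here, the only single-point step among them is a 1.7-fold lower number from compound 1 to compound 2 (0.24 log units; within the scatter). Compound 3 stands second highest of the three numbers, with the values of compound 1 and compound 3 lying within the scatter of each other and the values of compound 2 and compound 3 also within the scatter.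

Compound 4 `O=C(c1ccc(NCCO)cc1)C1CC1c1ccc(Cl)cc1` is the next compound to be measured in this assay. It differs from compound 3 as follows: hydroxy in place of pentyl on a saturated chain carbon, two bonds along the chain from a nitrogen on an aromatic ring. For the measured compounds named here, no measured step covers a change of this kind on the chain; the one measured step, at the aromatic nitrogen, stayed within the scatter, and the three numbers as a whole spread no further than that. A step of no size beyond the scatter is therefore expected in this assay, and the estimated step of a 1.0-fold higher number from compound 3 to compound 4 (0.00 log units; within the scatter) reflects that. For compound 4 the expected value in this assay is 400 ug/mL, within a range from 200 ug/mL to 800 ug/mL.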

Compound 4, half-maximal cytotoxic concentration: 305 ug/mL
Beside the measured number, compound 4's estimate is 1.3-fold (0.12 log units) above it, and the stated range covers the measured number.
By their numbers in this assay, from the lowest: compounds 2, 4, 3 and 1 (each within the scatter of the next).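

In this assay, among the compounds shown here, this is the first step on the chain itself, and it replaces pentyl with hydroxy, which gives heptylamino to (2-hydroxyethyl)amino overall (a 1.3-fold lower number from compound 3 to compound 4 (0.12 log units; within the scatter)). At this position, therefore, the 5 carbon atoms of pentyl give way to a single oxygen, adding a hydrogen-bond donor and acceptor, with the step remaining within the scatter. The earlier step, piperidin-1-yl in place of ((furan-2-yl)methyl)amino, exchanged the whole group on the aromatic carbon and gave no reading of the chain; no supporting data bear on this result.

The compounds shown leave open whether an amine or a carboxylic acid in place of hydroxy, or a longer chain ending in hydroxy, would give a step beyond the scatter. They also leave open whether the same change would read alike on the core of compound 1.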